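Lengthening the Amide Alkyl Group of Compound 1

The source may hold more compounds than are shown below. What is called first, only, known or untested is meant among the compounds shown, and "the series" means these compounds.

Compound 1 `CNC(=O)c1cc(Oc2ccc(NC(=O)c3cc4cccnc4n(-c4ccccc4)c3=O)cc2)ccn1` in a functional assay on NCI-H460 cells (Homo sapiens) for antiproliferative activity, read by MTT assay, with a stated time of 72 h; on this read-out lower numbers stand for stronger inhibition and higher numbers for weaker inhibition: 320 nM
Compound 2 `CNC(=O)c1cc(Oc2ccc(NC(=O)c3cc4cccnc4n(-c4ccc(Br)cc4)c3=O)cc2)ccn1` in this assay: 3710 nM
Compound 3 `CNC(=O)c1cc(Oc2ccc(NC(=O)c3cc4cccnc4n(-c4ccc(OC)cc4)c3=O)cc2)ccn1` in this assay: "not determined" (no result reported)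

Among the compounds with values here, compound 1 holds the lowest of the two numbers available, and the single measured step, a 12-fold higher number from compound 1 to compound 2 (1.06 log units; beyond the scatter), concerns a change on the aryl ring attached to the shared core. Compound 4 `CCNC(=O)c1cc(Oc2ccc(NC(=O)c3cc4cccnc4n(-c4ccccc4)c3=O)cc2)ccn1` differs from compound 1 only by methyl in place of hydrogen on a saturated chain carbon bound to an amide-type nitrogen. Within the data shown here, no measured step touches this amide chain, so the one known step does not bear on the change in hand. With no comparison to guide it, the number for compound 4 is expected to sit near that of compound 1, a step of a 1.3-fold higher number from compound 1 to compound 4 (0.10 log units; within the scatter) that need not exceed the usual scatter. Compound 4 is therefore estimated at 400 nM in this assay, within a range from 150 nM to 1200 nM.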

Compound 4, half-maximal inhibitory concentration: 1120 nM
The estimate for compound 4 lay 2.8-fold (0.45 log units) below the measured number; measured number inside the range.
By their numbers in this assay, from the lowest: compound 1; then compound 4; then compound 2.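

Within the data shown here, the first step on the amide chain shows that this position responds to a small change: going from methylcarbamoyl to ethylcarbamoyl gives a 3.5-fold higher number from compound 1 to compound 4 (0.54 log units; beyond the scatter) in this assay. A single added carbon is thus enough to move the number beyond the scatter, and the direction is towards weaker inhibition. No measurement shown gives a reason for this shift.

On these data alone, whether a longer chain such as propyl, or a ring such as cyclopropyl, would raise the number further remains open. So does the effect of an unsubstituted carbamoyl group, with no alkyl chain on the amide nitrogen at all.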